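Swapping an azetidine acyl cap for a sulfonyl cap

A few compounds are considered here, and "the series" means these few. Any claim that something is new, unique, unknown or untested is made for them only; others in the source may bear on it.

Compound 1 `CCN(CC)S(=O)(=O)c1ccc(S(=O)(=O)N2CCC[C@@H](C(=O)NC3CN(C(=O)C4CC4)C3)C2)cc1` was tested in a functional assay on MIA PaCa-2 cells (Homo sapiens) for inhibition, read by MTT assay, with a stated time of 7 days (a lower number here means a stronger inhibitor, a higher number a weaker inhibitor), where compound 1 gives 2800 nM. Going by the values given here, of the two numbers recorded so far it is the higher; the only comparison is compound 2 `CC(C)c1noc(N2CCN(C(=O)[C@@H]3CCCN(S(=O)(=O)c4ccc(S(=O)(=O)C5CCC5)cc4)C3)CC2)n1`, for which compound 2 gives 70 nM, a separation that lies beyond the usual scatter. Compound 2 differs from compound 1 in several places at once, so the two values show only the gap between them, not the weight of any single change. Compound 3 `CCN(CC)S(=O)(=O)c1ccc(S(=O)(=O)N2CCC[C@@H](C(=O)NC3CN(S(C)(=O)=O)C3)C2)cc1` keeps the core of compound 1 and alters only the cap on the four-membered ring: methylsulfonyl in place of cyclopropylcarbonyl on an amine nitrogen in a ring. Among the compounds with values here, no measured pair isolates this exchange, so the step is expected to be small, in either direction or none beyond the scatter, with a 1.1-fold higher number from compound 1 to compound 3 (0.03 log units; within the scatter) as the expected change. Compound 3 is accordingly estimated at 3000 nM, within a range of 1000 nM to 9000 nM.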

Compound 3, half-maximal inhibitory concentration: 2500 nM
The estimate for compound 3 lay 1.2-fold (0.08 log units) above the measured number; measured number inside the range.
By their numbers in this assay, from the lowest: compound 2; then compounds 3 and 1 (each within the scatter of the next).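

In this assay, going by these compounds alone, placing methylsulfonyl in place of cyclopropylcarbonyl on the amine nitrogen of the four-membered ring gives a 1.1-fold lower number from compound 1 to compound 3 (0.05 log units; within the scatter), the first reading of a change made in one place alone. The step lies within the scatter, so compound 1 and compound 3 cannot be told apart, even though the three-membered ring of the cap leaves and a sulfonyl group enters. No measurement offers an explanation for this result.

What a longer alkyl chain, a benzoyl group or a free amine hydrogen at this nitrogen would do remains open, since the two caps shown say nothing about these. Compound 2 differs from compound 1 and compound 3 in several places, so its much lower number cannot yet be assigned to any single part of the structure.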